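The source may report more compounds than this note shows. Statements on the series, on what has been measured and on what is new or still open speak of the compounds shown alone.

The series shares one core, shown in compound 1 `O=C1C(=O)N(Cc2ccc(-c3ccncc3)cn2)c2ccc(OC(F)(F)F)cc21`, for which the result in a functional assay on CHO cells for positive allosteric modulation of muscarinic acetylcholine receptor M5 (Homo sapiens), read by FLIPR and calcium flux, with a stated time of 1 h (a lower number here means a smaller maximal response, a higher number a larger maximal response), is "not determined" (no result reported). Two close relatives carry numbers. Compound 2 `O=C1C(=O)N(Cc2ccc(-c3cncnc3)cc2)c2ccc(OC(F)(F)F)cc21` gives 53% in this assay, and compound 3 `O=C1C(=O)N(Cc2ccc(-c3ccccc3)cc2F)c2ccc(OC(F)(F)F)cc21` gives 63% in this assay. For the measured compounds named here, the two values are within the usual scatter of each other, so no order between compound 2 and compound 3 can be read from them; among the numbers available, compound 2 stands at the lower end only in the narrowest sense, with no measured step separating it from any partner.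

The untested member is compound 4 `O=C1C(=O)N(Cc2ccc(-c3ccncc3)cc2)c2ccc(OC(F)(F)F)cc21`. Relative to compound 2 it differs in one place: pyridin-4-yl in place of pyrimidin-5-yl on an aromatic carbon. Going by the values given here, no pair of measured compounds shows this change, so the account has nothing beyond the two numbers above to rest on. Given that compound 2 gives 53% and that its single nearest neighbour sits within the scatter, the step is expected to be small and in no clear direction. The change from compound 2 to compound 4 is estimated as a number 5 percentage points higher from compound 2 to compound 4 (within the scatter), not beyond the scatter. Compound 4 is therefore expected to give about 58% in this assay, within a range from 40% to 78%.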

Compound 4, largest response reached (Emax), in percent of the reference or control that the assay uses: 60%
For compound 4 the middle estimate is 2 percentage points below the measured one, within the range that was stated.
By their numbers in this assay, from the lowest: compounds 2, 4 and 3 (each within the scatter of the next).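

For the compounds shown here, the first measured step at this position is small: in this assay, pyridin-4-yl in place of pyrimidin-5-yl gives a number 7 percentage points higher from compound 2 to compound 4 (within the scatter). On this aromatic carbon, para to a large group, the swap from a six-membered aromatic ring with 2 hetero atoms and 2 hydrogen-bond acceptors to one with 1 hetero atom and 1 hydrogen-bond acceptor therefore leaves no measurable difference in the largest response reached, so the exact number of ring nitrogens in this pair does not separate the two compounds. No measurement bears on why the two compounds read alike, so this single step gives no explanation for the result.

The compounds shown carry only six-membered aromatic rings at this place, so it remains open whether a non-aromatic group such as a morpholine, an amine or a carboxylic acid there would move the response beyond the usual scatter. Compound 3 differs from compound 4 in more than one place, so the separate contributions of its phenyl ring and its fluorine cannot be read from these numbers.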